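Trimethoxyphenyl series: carbonylmethylsulfanyl variant, cytotoxicity outlook

The source may hold more compounds than are shown below. What is called first, only, known or untested is meant among the compounds shown, and "the series" means these compounds.

For the measured compounds named here, compound 3 `COc1cc(-c2nnc(SCc3ccccc3Cl)n2N2C(=O)c3ccccc3C2=O)cc(OC)c1OC` is one of three compounds so far tested in a functional assay on PC-3M cells (Homo sapiens) for cytotoxicity, read by MTT assay, with a stated time of 48 h; a higher number here means a weaker inhibitor, a lower number a stronger inhibitor. In this assay compound 3 gives > 200000 nM, which is a limit of the assay and not a number. Compound 1 `Cc1nnc(SCC(=O)c2ccc(Cl)cc2)n1N1C(=O)c2ccccc2C1=O` in this assay gives > 200000 nM, again a limit. Compound 2 `CCc1nnc(SCC(=O)c2ccc(Cl)cc2)n1N1C(=O)c2ccccc2C1=O` in this assay gives > 200000 nM, also a limit. Going by the values given here, the only single-point step among the measured compounds, a step that the two limits leave unreadable from compound 1 to compound 2, is unreadable for that reason. All three values sit at the limit of > 200000 nM in this assay, at which 3 of the 3 values shown sit. Compound 4 `COc1cc(-c2nnc(SCC(=O)c3ccc(Cl)cc3)n2N2C(=O)c3ccccc3C2=O)cc(OC)c1OC` has not yet been measured. It differs from compound 3 by (4-chlorophenyl)carbonyl in place of 2-chlorophenyl on a saturated chain carbon bound to a sulfur. Among the compounds with values here, the same (((4-chlorophenyl)carbonyl)methyl)sulfanyl group is carried by compound 1 and compound 2, both at the limit, and the shared core of compound 3 with its trimethoxyphenyl is likewise at the limit, so no measured step gives a direction for this change. Compound 4 is therefore expected to remain at the limit, an expected step of a number no higher from compound 3 to compound 4 (the limit leaves the size open). The estimate for compound 4 in this assay is 200000 nM, with a range from 60000 nM to 700000 nM.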

Compound 4, half-maximal inhibitory concentration: 20700 nM
Estimate against measurement, compound 4: 9.7-fold (0.99 log units) above, outside the stated range (below it).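

In this assay, (4-chlorophenyl)carbonyl in place of 2-chlorophenyl on a saturated chain carbon bound to a sulfur gives an at least 9.6-fold lower number from compound 3 to compound 4 (0.98 log units; beyond the scatter), so this position responds to the change when 3,4,5-trimethoxyphenyl is present. With the (((4-chlorophenyl)carbonyl)methyl)sulfanyl group held constant, 3,4,5-trimethoxyphenyl gives an at least 9.6-fold lower number from compound 2 to compound 4 (0.98 log units; beyond the scatter) in place of ethyl and an at least 9.6-fold lower number from compound 1 to compound 4 (0.98 log units; beyond the scatter) in place of methyl. Neither group alone gives a readable value, and only compound 4, which carries both, has a number rather than a limit: the limit of > 200000 nM in this assay, at which 3 of the 4 values shown sit.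

The change from compound 3 adds the carbonyl and also differs in the chlorophenyl naming, so the compounds shown do not separate the contribution of the carbonyl from that of the chlorine placement. Also open, on these data alone, is how a simple phenyl in place of 3,4,5-trimethoxyphenyl, or an amine such as morpholine in place of 4-chlorophenyl, would read in this assay.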